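A few compounds are considered here, and "the series" means these few. Any claim that something is new, unique, unknown or untested is made for them only; others in the source may bear on it.

Compound 1, `Nc1cccc(-c2cn3nc(-c4ccccc4)sc3n2)c1`: 33000 nM
Compound 2, `Cc1ccc(-c2nn3cc(-c4cccc(N)c4)nc3s2)cc1`: 5900 nM
Compound 3, `Nc1cccc(-c2cn3nc(-c4ccc(Cl)cc4)sc3n2)c1`: > 250000 nM

All three compounds share one core and differ only in what sits on the outer phenyl ring, and all were tested in a functional assay on CCRF-CEM cells (Homo sapiens) for inhibition, read by cell counting, with a stated time of 3 days; a lower number here means a stronger inhibitor, a higher number a weaker inhibitor. Compound 1 carries a bare phenyl; compound 2 carries a methyl on it, and the step is a 5.6-fold lower number from compound 1 to compound 2 (0.75 log units; beyond the scatter). Compound 3 carries a chloro in that position. For compound 3 this assay reports only a limit, not a number. Compound 3 therefore stands at the limit of > 250000 nM in this assay, at which 1 of the 3 values shown sits. Measured against compound 1 the step is an at least 7.5-fold higher number from compound 1 to compound 3 (0.87 log units; beyond the scatter), and against compound 2 it is an at least 42-fold higher number from compound 2 to compound 3 (1.62 log units; beyond the scatter).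

Compound 4, `Nc1cccc(-c2cn3nc(-c4ccc(F)cc4)sc3n2)c1`, has not yet been measured. It differs from compound 3 in a single place: fluoro in place of chloro on an aromatic carbon. The two steps that bear on this position are those ending at compound 3, and both were rises beyond the scatter. Swapping the chloro for a fluoro is expected to move the number back toward that of compound 1, so a lower number than the limit of compound 3 is expected. Since compound 3 gives only a limit, the size of that step remains uncertain. Compound 4 is expected near 70000 nM, within 15000 nM to 250000 nM. The step that this estimate implies is expected to be an at least 3.5-fold lower number from compound 3 to compound 4 (0.55 log units; beyond the scatter).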

Compound 4, half-maximal inhibitory concentration: >= 250000 nM
Compound 4 gave a limit, no number (the forecaster's own chance of this, stated with the estimate: 30%); at least 3.5-fold (0.55 log units) between middle value and limit.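

The loss of strength seen with chloro is not particular to chloro: in this assay, fluoro in place of the hydrogen gives an at least 7.5-fold higher number from compound 1 to compound 4 (0.87 log units; beyond the scatter), and fluoro in place of the methyl gives an at least 42-fold higher number from compound 2 to compound 4 (1.62 log units; beyond the scatter). Among the four compounds shown, both halogens on this carbon, para to a large group, leave the compound weaker than the bare phenyl, while only the methyl of compound 2 gives a stronger inhibitor than compound 1. Compound 3 and compound 4 both end in limits rather than numbers, so the step between them cannot be read and neither halogen can be ranked against the other, as the entry for compound 4 shows: the limit of >= 250000 nM in this assay, at which 1 of the 4 values shown sits.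

On these data alone, it remains open whether the gain belongs to methyl alone or would also appear with an ethyl chain, a methoxy group or an amine in the same place. Also open, as far as these compounds go, is how weak compound 3 and compound 4 really are, since their limits mark only where the readings stop.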